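This account rests on a few compounds, and the source may have more. Where it says the series, first, only, none or still open, it means among the compounds named here.

Of the compounds shown here, two have so far been measured in a functional assay (L1210 cells) for inhibition, with Mus musculus as the target; a higher number here means a weaker inhibitor, a lower number a stronger inhibitor. Compound 1 `C#CCN(Cc1cc2c(O)nc(C)nc2cc1C)c1ccc(C(=O)N[C@@H](CCC(=O)O)C(=O)N(C)[C@@H](CCC(=O)O)C(=O)O)c(F)c1` gives 340 nM in this assay, the lower of the two numbers, and compound 2 `C#CCN(Cc1ccc2nc(C)nc(O)c2c1)c1ccc(C(=O)N[C@@H](CC(C)C(=O)O)C(=O)N[C@@H](CCC(=O)O)C(=O)O)cc1` gives 410 nM; these two values lie within the scatter of each other, so neither compound can be called the stronger inhibitor. Compound 3 `C#CCN(Cc1cc2c(O)nc(C)nc2cc1C)c1ccc(C(=O)N[C@@H](CCC(=O)O)C(=O)N(CC)[C@@H](CCC(=O)O)C(=O)O)c(F)c1` has not yet been measured. It differs from compound 1 in one place: methyl in place of hydrogen on a saturated chain carbon bound to an amide-type nitrogen. Cut one bond further out, the change reads methyl to ethyl, that is, (1,3-dicarboxypropyl)(methyl)amino to (1,3-dicarboxypropyl)(ethyl)amino. Among the measured compounds shown here, no measured pair shows what such a change does here, so the expectation rests on the smallness of the change alone. The step of a 1.3-fold higher number from compound 1 to compound 3 (0.12 log units; within the scatter) is expected to stay within or near the scatter, leaning if anything toward a weaker inhibitor. The estimate for compound 3 is 450 nM, with a range from 150 nM to 1400 nM.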

Compound 3, half-maximal inhibitory concentration: 70 nM
Compound 3: the middle estimate sits 6.4-fold (0.81 log units) above what was measured, outside the stated range (below it).
By their numbers in this assay, from the lowest: compound 3; then compounds 1 and 2 (each within the scatter of the next).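

In this assay, the change from methyl to ethyl on the amide-type nitrogen gives a 4.9-fold lower number from compound 1 to compound 3 (0.69 log units; beyond the scatter), so this position responds to the addition of a single carbon. The change adds no ring, no hydrogen-bond donors or acceptors and no net charge, yet its step lies beyond the scatter, so the size of a change alone is a poor guide here. Nothing available explains why the extra methyl on this saturated chain carbon gives a lower number.

A single pair cannot show whether the trend continues with a longer chain, such as propyl, or reverses. It also leaves open what a ring such as cyclopropyl, or an amine or a hydroxyl group at the end of the ethyl chain, would do at this place.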